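The compounds below may be only part of what the source reports. "The series", "measured", "known", "first", "only" and "open" are said of these compounds alone.

Three compounds have been measured in a functional assay on ASPC1 cells (Homo sapiens) for inhibition, read by MTT assay, with a stated time of 72 h; on this read-out higher numbers stand for weaker inhibition of growth and lower numbers for stronger inhibition of growth:
compound 1, `O=S(=O)(NCCCNCc1ccc(Cl)c(Cl)c1)c1cc(C(F)(F)F)cc(C(F)(F)F)c1`, with 2800 nM;
compound 2, `O=S(=O)(NCCCNCc1ccc(C(F)(F)F)cc1)c1cc(C(F)(F)F)cc(C(F)(F)F)c1`, with 2000 nM;
compound 3, `O=S(=O)(NCCCNCc1ccc(-c2ccccc2)cc1)c1cc(C(F)(F)F)cc(C(F)(F)F)c1`, with 2500 nM.

Compound 1 gives the highest of these three numbers, yet its gap to compound 3 and its gap to compound 2 are both within the scatter, so no real order among the three can be read from them. Compound 4, `O=S(=O)(NCCCNCc1ccc(Cl)cc1)c1cc(C(F)(F)F)cc(C(F)(F)F)c1`, is not yet measured. It differs from compound 1 in one place: hydrogen in place of chloro on an aromatic carbon. Both measured steps alter the group on the saturated chain carbon bound to the amine nitrogen, the same part of the molecule: a 1.4-fold lower number from compound 1 to compound 2 (0.15 log units; within the scatter) and a 1.3-fold higher number from compound 2 to compound 3 (0.10 log units; within the scatter). Going by the values given here, neither of them replaces a chloro group with hydrogen, so no measured step bears directly on this change. What they do show is that exchanging groups on this part of the molecule has hardly moved the number. For compound 4 the step of a 1.1-fold higher number from compound 1 to compound 4 (0.03 log units; within the scatter) is therefore expected to remain within the scatter. Compound 4 is estimated at 3000 nM, with a range from 1500 nM to 6000 nM.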

Compound 4, concentration for 50% growth inhibition: 3000 nM
Estimate against measurement, compound 4: no gap at the digits printed, within the range that was stated.
By their numbers in this assay, from the lowest: compounds 2, 3, 1 and 4 (each within the scatter of the next).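

The first direct test of removing a chloro group, going from 3,4-dichlorophenyl to 4-chlorophenyl, gives a 1.1-fold higher number from compound 1 to compound 4 (0.03 log units; within the scatter) in this assay and so shows that hydrogen and chloro at this ring position cannot be told apart here. Alongside it stand a 1.2-fold higher number from compound 3 to compound 4 (0.08 log units; within the scatter) and a 1.5-fold higher number from compound 2 to compound 4 (0.18 log units; within the scatter) as well, so chloro, phenyl and trifluoromethyl on this ring also cannot be told apart. No other measurement is at hand to explain this flat picture.

The compounds shown leave open whether a hydroxyl, an amine or a carboxylic acid on this ring would move the number, or whether an unsubstituted phenyl would. They also leave open whether a longer chain in the shared core would change it.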